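Anilino in place of phenyl on the thioether chain

A few compounds are considered here, and "the series" means these few. Any claim that something is new, unique, unknown or untested is made for them only; others in the source may bear on it.

Of the compounds shown here, three sharing one core have been measured in an assay on HEK293 cells for displacement of a labelled ligand from prostaglandin D2 receptor 2 (Homo sapiens); on this read-out higher numbers stand for weaker inhibition and lower numbers for stronger inhibition. Compound 1 `O=C(O)Cn1c(SCCOc2cccc3ccccc23)nc2ccccc21` gives 2000 nM. Compound 2 `O=C(O)Cn1c(SCCCCOc2ccccc2)nc2ccccc21` gives 1400 nM. Compound 3 `O=C(O)Cn1c(SCCCc2ccccc2)nc2ccccc21` gives 475 nM, the lowest of the three numbers; compound 2 stands nearest to it and compound 1 furthest, both beyond the scatter. For the measured compounds named here, the one single-point step among them, a 2.9-fold lower number from compound 2 to compound 3 (0.47 log units; beyond the scatter), runs from phenoxymethyl to phenyl and lowers the number.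

Compound 4 `O=C(O)Cn1c(SCCCNc2ccccc2)nc2ccccc21` differs from compound 3 by anilino in place of phenyl on a saturated chain carbon, three bonds along the chain from a sulfur. The anilino group brings one hydrogen-bond donor and one hydrogen-bond acceptor where phenyl has none, and it places the aromatic ring one atom further from the sulfur, much as phenoxymethyl does in compound 2. Going by the values given here, the only step that bears on this is a 2.9-fold lower number from compound 2 to compound 3 (0.47 log units; beyond the scatter), in which the shorter, heteroatom-free link gave the lower number; the new change goes the other way, so a modest rise in this assay is expected, with wide uncertainty since no anilino compound has been measured. The estimated step is a 2.1-fold higher number from compound 3 to compound 4 (0.32 log units; beyond the scatter). Compound 4 is therefore expected to give 1000 nM, within a range from 400 nM to 2500 nM.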

Compound 4, half-maximal inhibitory concentration: 2690 nM
Compound 4: middle estimate off by 2.7-fold (0.43 log units), on the low side, outside the stated range (above it).
By their numbers in this assay, from the lowest: compound 3; then compounds 2, 1 and 4 (each within the scatter of the next).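

In this assay, anilino in place of phenyl on a saturated chain carbon, three bonds along the chain from a sulfur, gives a 5.7-fold higher number from compound 3 to compound 4 (0.75 log units; beyond the scatter) and so clearly moves away from the stronger inhibition seen with phenyl. Anilino in place of phenoxymethyl at the same place gives a 1.9-fold higher number from compound 2 to compound 4 (0.28 log units; within the scatter), so these two groups cannot be told apart here, even though one holds a nitrogen and the other an oxygen, and phenyl alone stands apart from them among the groups compared at this position. No information is available on why the change from phenyl to anilino has this effect.

Anilino differs from phenyl in both its added nitrogen and the greater reach of its ring, and these compounds cannot separate the two: benzyl at this place would keep the extra reach without the nitrogen. Phenoxy would match anilino with an oxygen in place of the nitrogen, and N-methylanilino would show whether the hydrogen on that nitrogen matters.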